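Hydroxy for dimethylamino on the aryl of compound 1

The source may report more compounds than this note shows. Statements on the series, on what has been measured and on what is new or still open speak of the compounds shown alone.

Measured compounds:
- compound 1 `CN(C)c1cccc(-c2nc3c(=O)n(C)c(=O)n(C)c3[nH]2)c1`: 80 nM
- compound 2 `CCCn1c(=O)c2nc(-c3ccc(Cl)cc3N)[nH]c2n(CCC)c1=O`: 0.05 nM
- compound 3 `CCn1c(=O)c2nc(-c3ccc(S(=O)(=O)NCCN(C)C)cc3)[nH]c2n(CC)c1=O`: 3.3 nM

In an assay for binding affinity to adenosine receptor A1 (Bos taurus) (on this read-out higher numbers stand for weaker inhibition and lower numbers for stronger inhibition), compound 1 gives 80 nM, the highest number of the three. The nearest number is that of compound 3 with 3.3 nM, and the lowest is that of compound 2 with 0.05 nM; both gaps to compound 1 lie beyond the scatter. Compounds 2 and 3 carry larger groups on the core and different aryl substitution, so no single change links them to compound 1.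

Compound 4 `Cn1c(=O)c2nc(-c3cccc(O)c3)[nH]c2n(C)c1=O` is the next compound of the series. The change from compound 1 is hydroxy in place of dimethylamino on an aromatic carbon, on an aromatic carbon of a six-membered aromatic ring of carbon only, meta to a large group. Among the measured compounds shown here, no measured pair in this set shows this change, so the size of the step is open. A small step in this assay is expected, one not clearly beyond the scatter in either direction, given that the core and the aryl ring of compound 1 are kept.

The expected step from compound 1 to compound 4 is a 1.3-fold lower number from compound 1 to compound 4 (0.12 log units; within the scatter). Compound 4 is estimated at 60 nM, with a range from 15 nM to 250 nM.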

Compound 4, half-maximal inhibitory concentration: 6 nM
The estimate for compound 4 lay 10-fold (1.00 log units) above the measured number; measured number below the stated range.
By their numbers in this assay, from the lowest: compound 2; then compounds 3 and 4 (each within the scatter of the next); then compound 1.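

In this assay, hydroxy in place of dimethylamino on an aromatic carbon, meta to a large group, gives a 13-fold lower number from compound 1 to compound 4 (1.12 log units; beyond the scatter) with the shared core kept, a large step that shows this aryl position has a strong bearing on the read-out. Compounds 1, 2 and 3 could not show this, as no single change linked any two of them. The heavy-atom count and the count of hydrogen-bond donors change together in this one pair, and nothing measured here separates the two or gives a reason for the step.

The compounds shown hold no other group at this place, so methoxy, a primary amine or a carboxylic acid would be needed to tell whether the step belongs to hydroxy itself or to the loss of dimethylamino. Also open, going by these compounds, is whether the same change keeps its size on a core with longer chains, such as the ethyl chains of compound 3 or the propyl chains of compound 2.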